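Varying the aryl group on the sulfonyl sulfur

The source may report more compounds than this note shows. Statements on the series, on what has been measured and on what is new or still open speak of the compounds shown alone.

compound 1, `CCN(CC)Cc1ccc(S(=O)(=O)NCc2ccc(CNC(=O)c3ccc(F)cc3)cc2)cc1`: 1 nM
compound 2, `O=C(NCc1ccc(CNS(=O)(=O)c2ccc(-c3ccc(F)cc3)cc2)cc1)c1ccc(F)cc1`: 100 nM
compound 3, `O=C(NCc1ccc(CNS(=O)(=O)c2ccc(Cl)cc2)cc1)c1ccc(F)cc1`: 100 nM

In an assay on MDA-MB-231 cells for binding affinity to C-X-C chemokine receptor type 4 (Homo sapiens), read by fluorescence and microscopy, with stated times of 10 min and 30 min (on this read-out higher numbers stand for an effect only at larger amounts of compound and lower numbers for an effect already at smaller amounts), compound 1 gives 1 nM, compound 2 gives 100 nM and compound 3 gives 100 nM. Compound 3 thus stands level with compound 2, the two together the highest numbers of the three, and far from compound 1: a 100-fold higher number from compound 1 to compound 3 (2.00 log units; beyond the scatter). Compound 4, `O=C(NCc1ccc(CNS(=O)(=O)c2cccc(C(F)(F)F)c2)cc1)c1ccc(F)cc1`, differs from compound 3 in one place: 3-(trifluoromethyl)phenyl in place of 4-chlorophenyl on a sulfonyl sulfur. Among the compounds with values here, no measured step exchanges one aryl group on the sulfonyl sulfur for another of this kind; the nearest is no change at the digits printed from compound 2 to compound 3 (within the scatter), while a 100-fold higher number from compound 1 to compound 2 (2.00 log units; beyond the scatter) and a 100-fold higher number from compound 1 to compound 3 (2.00 log units; beyond the scatter) concern the (diethylamino)methyl group, which compounds 3 and 4 both lack. Compound 4 is therefore expected to give a number within the usual scatter, no change at the digits printed from compound 3 to compound 4 (within the scatter), estimated in this assay at 100 nM with a range from 30 nM to 300 nM.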

Compound 4, effective concentration (reported as EC, without a stated level of effect): 100 nM
Compound 4: the middle estimate sits on the measured number at the digits printed; the range from low to high includes it.
By their numbers in this assay, from the lowest: compound 1; then compounds 2, 3 and 4 (each within the scatter of the next).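

In this assay, putting 3-(trifluoromethyl)phenyl in place of 4-chlorophenyl on the sulfonyl sulfur gives no change at the digits printed from compound 3 to compound 4 (within the scatter), even though the entering group has 10 heavy atoms against 7 for the group it replaces. Compound 4 thus prints the same value as compound 2 and compound 3, making a third aryl group without the (diethylamino)methyl group at this number. Nothing given here explains this result. From the compounds shown here alone, whether another amine, such as a piperidine or morpholine, or a carboxylic acid on this aryl group would reach the lower number of compound 1 remains open.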